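The compounds below may be only part of what the source reports. "The series", "measured", "known", "first", "only" and "open" are said of these compounds alone.

For the measured compounds named here, compound 1 `O=C(Nc1ccc(Cl)cc1)C1CCCN(C(=O)c2cccc(-c3cccs3)c2)C1` is the one compound here with a numerical reading: in a functional assay on PC-3 cells (Homo sapiens), with a stated time of 24 h, tested at 10 uM (a lower number here means less inhibition, a higher number more inhibition at the concentration tested (going by the name of the read-out)), compound 1 gives 70%. Compound 2 `O=C(Nc1cccc(Oc2ccccc2)c1)C1CCCN(C(=O)c2cc(C(F)(F)F)cc(C(F)(F)F)c2)C1` carries a phenoxy group, and for compound 2 the assay returned only a limit, < 30%. Compound 3 `O=C(Nc1cccc(Cc2ccccc2)c1)C1CCCN(C(=O)c2cc(C(F)(F)F)cc(C(F)(F)F)c2)C1` is its benzyl counterpart, and for compound 3 too the reading is a limit, < 30%. Going by the values given here, the only single-point step between measured compounds, a step that the two limits leave unreadable from compound 2 to compound 3, cannot be sized because of the limit of < 30% in this assay, at which 2 of the 3 values shown sit. Compound 4 `Cc1nc(-c2cccc(NC(=O)C3CCCN(C(=O)c4cc(C(F)(F)F)cc(C(F)(F)F)c4)C3)c2)cs1` differs from compound 3 by 2-methyl-1,3-thiazol-4-yl in place of benzyl on an aromatic carbon. Among the compounds with values here, no measured step bears on this exchange, and compound 1, the sole numerical value, differs from compound 4 in more than one place, so it gives no direct guide. Compound 4 is therefore expected to remain close to where compound 3 stands, with a step of a number no lower from compound 3 to compound 4 (the limit leaves the size open) as the estimate. The estimate for compound 4 in this assay is 30%, with a range from 12% to 55%.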

Compound 4, a percentage reported as inhibition, at one concentration (the size of the read-out at that concentration, not a potency): 42%
Compound 4: the middle estimate sits 12 percentage points below what was measured, within the range that was stated.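

In this assay, putting 2-methyl-1,3-thiazol-4-yl in place of benzyl gives a number at least 12 percentage points higher from compound 3 to compound 4 (beyond the scatter), and putting it in place of phenoxy gives a number at least 12 percentage points higher from compound 2 to compound 4 (beyond the scatter). The aromatic carbon meta to a large group is thus a place where the group can lift the reading clear of the limit with the rest of the molecule unchanged, which the earlier pair could not show. Both sizes are only lower bounds, and the step between compound 2 and compound 3 cannot be read, because those compounds sit at a limit: the limit of < 30% in this assay, at which 2 of the 4 values shown sit.

The compounds shown do not separate the five-membered aromatic ring from its methyl group, and they leave open how an unsubstituted 1,3-thiazol-4-yl, a pyridine ring or an amine would read at this place. They also do not say whether the same exchange would raise the reading on the acyl side carried by compound 1.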